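Working notes: the mirror image of compound 2

The source may hold more compounds than are shown below. What is called first, only, known or untested is meant among the compounds shown, and "the series" means these compounds.

Measured in a functional assay (ileum) with Cavia porcellus as the target; a higher number here means a more potent compound, by a factor of ten per unit of this negative logarithm, a lower number a less potent compound:
- compound 1 `COC(=O)C1CC2CNC1C2`: 6.2
- compound 2 `COC(=O)[C@@H]1C[C@H]2CN[C@@H]1C2`: 6

Compound 2 stands within the scatter of compound 1. Compound 3 `COC(=O)[C@H]1C[C@@H]2CN[C@H]1C2` is not yet measured, and its relation to compound 2 is this: the two compounds have the same atoms and bonds and differ only in configuration as drawn: 3 of 3 stereo elements differ (all stereocentres are inverted: mirror images); a stereocentre at a saturated ring carbon is drawn R in compound 2 and S in compound 3; a stereocentre at a saturated ring carbon is drawn R in compound 2 and S in compound 3; a stereocentre at a saturated ring carbon is drawn R in compound 2 and S in compound 3. Within the data shown here, only one measured step bears on the change, a number 0.20 log units lower from compound 1 to compound 2 (within the scatter), and it goes with the fact that one of compounds 1 and 2 is drawn with a defined configuration and the other without, at the place where they differ. Since that step is small, with compound 1 carrying no drawn configuration, no step beyond the scatter is expected in this assay, and the expected direction is only weakly upward. The expected step is a number 0.30 log units higher from compound 2 to compound 3 (within the scatter). For compound 3 the estimated value is 6.3, with an expected range of 5.8 to 6.8.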

Compound 3, negative logarithm of the half-maximal effective concentration: 5.2
The estimate for compound 3 lay 1.10 log units above the measured number; the measured number lies below the stated range.
By their numbers in this assay, from the lowest: compound 3; then compounds 2 and 1 (each within the scatter of the next).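

In this assay, the configuration of the shared core matters, which the step involving compound 1, drawn without configuration, could not show: inverting all three stereocentres gives a number 0.80 log units lower from compound 2 to compound 3 (beyond the scatter). Against compound 1 the result is a number 1.00 log units lower from compound 1 to compound 3 (beyond the scatter), while compound 2 stays within the scatter of compound 1. The two mirror images are therefore not equivalent in this assay, a gap tied to configuration alone: the fact that compounds 2 and 3 differ only in the configuration as drawn

Which of the three stereocentres carries the gap remains open, as only full inversion is shown. From the compounds shown here alone, whether the same order holds with a carboxylic acid or an ethyl ester in place of the methyl ester also remains open.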